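Changing the Group on the Carbonyl Carbon of Compound 2

This account rests on a few compounds, and the source may have more. Where it says the series, first, only, none or still open, it means among the compounds named here.

In a functional assay on MDA-MB-231 cells (Homo sapiens) for inhibition, read by MTT assay, with a stated time of 48 h (on this read-out lower numbers stand for stronger inhibition and higher numbers for weaker inhibition), compound 2 (`COc1ccc(N(C)c2nc(C)nc3ccccc23)cc1C(=O)NCC[Se]C#N`) gives 1250 nM, which lies within the scatter of compound 1 (`COc1ccc(N(C)c2nc(C)nc3ccccc23)cc1OCCC[Se]C#N`) at 815 nM. Compound 3 (`COc1ccc(N(C)c2nc(C)nc3ccccc23)cc1C(=O)OCCCCC[Se]C#N`) differs from compound 2 on a carbonyl carbon: a group of 9 heavy atoms (6 carbon, 1 nitrogen, 1 oxygen, 1 selenium; no ring) in place of a group of 6 heavy atoms (3 carbon, 2 nitrogen, 1 selenium; no ring), on a carbonyl carbon. Among the compounds with values here, only one measured step bears on this change, a 1.5-fold higher number from compound 1 to compound 2 (0.19 log units; within the scatter), and it involves a different group exchange on an aromatic carbon. With that single small step as a guide, no shift beyond the scatter is expected, and the expected change is a 1.4-fold lower number from compound 2 to compound 3 (0.14 log units; within the scatter). Compound 3 is estimated at 900 nM, with an expected range of 250 nM to 2500 nM.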

Compound 3, half-maximal inhibitory concentration: 851 nM
For compound 3 the middle estimate is 1.1-fold (0.02 log units) above the measured one; the range from low to high includes it.
By their numbers in this assay, from the lowest: compounds 1, 3 and 2 (each within the scatter of the next).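

In this assay, within the data shown here, the step at this carbonyl carbon stays within the scatter (a 1.5-fold lower number from compound 2 to compound 3 (0.17 log units; within the scatter)), the first measured exchange at this place. The group of 9 heavy atoms, with 0 hydrogen-bond donors, thus gives a value in the same range as the group of 6 heavy atoms, with 1 hydrogen-bond donor. No available evidence accounts for this result. The compounds shown leave open how a carboxylic acid, an amine or a much longer chain would behave on this carbonyl carbon. They also leave open whether a chain without selenium would stay in this range.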